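The source may report more compounds than this note shows. Statements on the series, on what has been measured and on what is new or still open speak of the compounds shown alone.

Measured so far:
Compound 1, `CCC[C@@H](OC(C)=O)C1=C(Br)C(=C(Br)Br)OC1=O`: 3.5 ug/mL
Compound 2, `CCCCC1=C(Br)/C(=C/Br)OC1=O`: > 20 ug/mL

Among the compounds with values here, in a functional assay on KB cells (Homo sapiens) for cytotoxicity (on this read-out lower numbers stand for an effect already at smaller amounts and higher numbers for an effect only at larger amounts of compound), compound 1 gives 3.5 ug/mL, and it is the only compound with an actual number here. For compound 2 the result is a limit of the assay, > 20 ug/mL, not a number. So compound 1 stands as the sole measured point, the other result being (the limit of > 20 ug/mL in this assay, at which 1 of the 2 values shown sits). Within the data shown here, no pair of measured compounds differs in just one place, so the size of a single structural change cannot be read from measured data in this set.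

Compound 3, `CCCCC1=C(Br)C(=C(Br)Br)OC1=O`, differs from compound 1 in one place: hydrogen in place of acetoxy on a saturated chain carbon bound to a double-bonded ring carbon and a saturated chain carbon. Compound 3 has not yet been measured in this assay. Since compound 2 sits at the limit of > 20 ug/mL in this assay, at which 1 of the 2 values shown sits, the expectation leans toward a weaker effect for compound 3. The change is expected to be a 4.3-fold higher number from compound 1 to compound 3 (0.63 log units; beyond the scatter), a step beyond the scatter toward higher numbers. Compound 3 is expected at 15 ug/mL, within 5 ug/mL and 40 ug/mL, with a fair chance that only a limit is reported.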

Compound 3, concentration for half-maximal effect: > 20 ug/mL
Compound 3: no number, only a limit; the forecaster's own chance of this, stated with the estimate: 45%; middle value at least 1.3-fold (0.12 log units) away from the limit.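

In this assay, within the data shown here, putting hydrogen in place of acetoxy on a saturated chain carbon bound to a double-bonded ring carbon and a saturated chain carbon gives an at least 5.7-fold higher number from compound 1 to compound 3 (0.75 log units; beyond the scatter), and this is the first comparison in the set in which only one place changes. Compound 3 gives > 20 ug/mL, which is a limit of the assay and not a number. The comparison therefore shows that the result depends on what sits on this chain carbon, since with the rest of the structure unchanged, the acetoxy group separates a measurable effect from none within the tested range, but the full size of the step stays unknown because the read-out stops at a limit:  the limit of > 20 ug/mL in this assay, at which 2 of the 3 values shown sit.

The compounds shown leave open whether the whole acetoxy group is needed or whether a smaller group on the same carbon, such as a hydroxyl, would give a similar number. They also do not show how a longer ester or an amine at this carbon would compare with acetoxy in this assay.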